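A fluorine on the N-phenyl ring of a thiazolidinone amide

The compounds below may be only part of what the source reports. "The series", "measured", "known", "first", "only" and "open" are said of these compounds alone.

Of the compounds shown here, two have been measured so far in a functional assay on SJSA-1 cells (Homo sapiens) for inhibition, read by CCK-8 assay, with a stated time of 72 h, tested at 1 uM; a higher number here means more inhibition at the concentration tested (going by the name of the read-out), a lower number less inhibition. Compound 1 `COc1ccc(F)cc1N1C(=O)CSC1c1cccc(C(=O)NCCCCc2ccccc2)c1` carries a 5-fluoro-2-methoxyphenyl on the amide-type nitrogen in the ring and gives 76%. Compound 2 `O=C(NCCCCc1ccccc1)c1cccc(C2SCC(=O)N2c2ccccc2)c1` carries a plain phenyl there and gives 73%. The one step between them, a number 3 percentage points lower from compound 1 to compound 2 (within the scatter), lies within the scatter, so the two numbers do not separate, and compound 2 stands level with compound 1 on the numbers shown.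

Compound 3 `O=C(NCCCCc1ccccc1)c1cccc(C2SCC(=O)N2c2cccc(F)c2)c1` is the next compound: fluoro in place of hydrogen on an aromatic carbon. Among the compounds with values here, the only measured step that bears on it is the one from compound 1 to compound 2, where a fluorine is one of two groups lost from that ring, and that step was within the scatter. A single fluoro added back to the phenyl of compound 2 is therefore expected to leave the read-out about where it is, with a number 1 percentage points higher from compound 2 to compound 3 (within the scatter), no step beyond the scatter in either direction. For compound 3 the estimate in this assay is 74%, with a range from 62% to 85%.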

Compound 3, a percentage reported as inhibition, at one concentration (the size of the read-out at that concentration, not a potency): 80%
The estimate for compound 3 lay 6 percentage points below the measured number; measured number inside the range.
By their numbers in this assay, from the lowest: compounds 2, 1 and 3 (each within the scatter of the next).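

In this assay, the fluoro on the ring at the amide-type nitrogen can now be read on its own: the change from phenyl to 3-fluorophenyl gives a number 7 percentage points higher from compound 2 to compound 3 (within the scatter). The methoxy can also be read on its own, since hydrogen in its place on the aromatic carbon gives a number 4 percentage points higher from compound 1 to compound 3 (within the scatter). The earlier step had exchanged two groups at once, whereas these two steps separate them, and neither change takes the read-out beyond the scatter, so phenyl, 3-fluorophenyl and 5-fluoro-2-methoxyphenyl stand level on the numbers shown, and no evidence at hand accounts for these numbers.

Going by these compounds, what stays open is whether a different kind of group on this ring, such as a carboxylic acid or an amine, or a longer chain in place of the one on the side amide, would give a step beyond the scatter. The numbers also come from one concentration and are no potencies, so they leave open whether these three compounds would separate at lower concentrations.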